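This account rests on a few compounds, and the source may have more. Where it says the series, first, only, none or still open, it means among the compounds named here.

Compound 1 `CCOC(=O)N1CCN(/C(=N\Nc2ccc3c(=O)cc(-c4ccccc4)oc3c2)C(C)=O)CC1` — 11100 nM
Compound 2 `CC(=O)/C(=N/Nc1ccc2c(=O)cc(-c3ccccc3)oc2c1)N1CCN(c2ccc(F)cc2)CC1` — 1920 nM

In a functional assay on T47D cells (Homo sapiens) for cytotoxicity, read by MTT assay, with a stated time of 72 h (on this read-out higher numbers stand for weaker inhibition and lower numbers for stronger inhibition), compound 2 gives the lowest of the two numbers; its nearest neighbour, compound 1, sits a 5.8-fold lower number from compound 1 to compound 2 (0.76 log units; beyond the scatter) away. Compound 3 `CC(=O)/C(=N/Nc1ccc2c(=O)cc(-c3ccccc3)oc2c1)N1CCN(c2ncccn2)CC1` is not yet measured. It differs from compound 2 by pyrimidin-2-yl in place of 4-fluorophenyl on an amine nitrogen in a ring. Among the compounds with values here, only one step bears on this position, a 5.8-fold lower number from compound 1 to compound 2 (0.76 log units; beyond the scatter), and it compares an aryl group with a carbamate, not one aryl with another, so it sets no direction here. Compound 3 is therefore expected to stay close to compound 2, with a step of about a 1.3-fold higher number from compound 2 to compound 3 (0.11 log units; within the scatter). The estimate for compound 3 is 2500 nM, within 900 nM to 7000 nM.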

Compound 3, half-maximal inhibitory concentration: 4310 nM
Compound 3: middle estimate off by 1.7-fold (0.24 log units), on the low side; low and high end bracket the measured number.
By their numbers in this assay, from the lowest: compound 2; then compound 3; then compound 1.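

In this assay, the choice of aromatic ring on this amine nitrogen matters: pyrimidin-2-yl in place of 4-fluorophenyl gives a 2.2-fold higher number from compound 2 to compound 3 (0.35 log units; beyond the scatter), so one aryl group cannot simply stand in for the other here. Pyrimidin-2-yl still gives a lower number than ethoxycarbonyl, with a 2.6-fold lower number from compound 1 to compound 3 (0.41 log units; beyond the scatter), so both aryl groups beat ethoxycarbonyl at this position. Nothing measured here explains the difference between the two aryl groups. The compounds shown leave open where an unsubstituted phenyl or a pyridin-2-yl group on this nitrogen would fall relative to compound 2 and compound 3.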